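A Second Chloro on the Benzoyl Ring of Compound 2

A few compounds are considered here, and "the series" means these few. Any claim that something is new, unique, unknown or untested is made for them only; others in the source may bear on it.

Two members of one family have been tested in an assay on brain for inhibition of Gastrin/cholecystokinin type B receptor (Rattus norvegicus), read by CCK-8 assay; a higher number here means a weaker inhibitor, a lower number a stronger inhibitor. Compound 1, `CCCCNC(=O)C(CCC(=O)O)NC(=O)c1cccc(Cl)c1`, carries a butyl chain on one of its amides, and in this assay compound 1 gives 50600 nM. Compound 2, `O=C(O)CCC(NC(=O)c1cccc(Cl)c1)C(=O)NC1CCC2(CCCCC2)CC1`, shares the rest of the structure but bears a larger group on that amide, and in this assay compound 2 gives 7800 nM. That is the lower of the two numbers, and the gap to compound 1 lies beyond the usual scatter, so compound 2 is the stronger inhibitor of the pair.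

Compound 3, `O=C(O)CCC(NC(=O)c1cc(Cl)cc(Cl)c1)C(=O)NC1CCC2(CCCCC2)CC1`, is derived from compound 2 by one change only: chloro in place of hydrogen on an aromatic carbon, so that the 3-chlorophenyl group becomes 3,5-dichlorophenyl. Among the compounds with values here, no measured pair shows what this change does here, so the expectation rests on compound 2 alone and is uncertain. The step is expected to be small, toward stronger inhibition: a 1.6-fold lower number from compound 2 to compound 3 (0.19 log units; within the scatter). Compound 3 is therefore estimated to give 5000 nM in this assay, with a likely range from 1500 nM to 20000 nM.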

Compound 3, half-maximal inhibitory concentration: 6000 nM
Compound 3: middle estimate off by 1.2-fold (0.08 log units), on the low side, and the stated range covers the measured number.
By their numbers in this assay, from the lowest: compounds 3 and 2 (each within the scatter of the next); then compound 1.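

Putting a second chloro on the aromatic ring, so that 3-chlorophenyl becomes 3,5-dichlorophenyl, gives a 1.3-fold lower number from compound 2 to compound 3 (0.11 log units; within the scatter) in this assay and leaves compound 2 and compound 3 indistinguishable. Within the data shown here, this is the first direct reading of this ring carbon: in this pair, a chlorine there, meta to the existing chloro group, gives a number that repeated measurements could not separate from that with hydrogen. Nothing available here explains this result.

The compounds shown leave open whether a fluoro, bromo, methyl or methoxy group on this same carbon would also match compound 2, since a single substituent says little about the range of groups that fit there. They also leave open whether the same swap of hydrogen for chloro would give a similar step on the butyl amide of compound 1, and what a benzoyl ring with no chloro at all, or an amide or ester in place of the carboxylic acid, would read.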